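Chloro in Place of Bromo: From Compound 3 to Compound 4

The compounds below may be only part of what the source reports. "The series", "measured", "known", "first", "only" and "open" are said of these compounds alone.

Of the compounds shown here, three sharing one core have been measured in a functional assay on DU-145 cells (Homo sapiens) for inhibition, read by trypan blue exclusion, with a stated time of 96 h; a higher number here means a weaker inhibitor of growth, a lower number a stronger inhibitor of growth. Compound 1 `COc1ccc(/C=C(/SCc2ccc(F)cc2)C(=O)c2ccc(Br)cc2)cc1O` gives 1000 nM. Compound 2 `Cc1cc(F)ccc1/C=C(/SCc1ccc(F)cc1)C(=O)c1ccc(Br)cc1` gives 10000 nM, and compound 3 `O=C(/C(=C\c1ccc(O)cc1)SCc1ccc(F)cc1)c1ccc(Br)cc1` gives 10000 nM. Compound 3 thus stands level with compound 2 at the highest numbers of the three, the step of no change at the digits printed from compound 2 to compound 3 (within the scatter) lying within the scatter, while the steps of a 10-fold higher number from compound 1 to compound 2 (1.00 log units; beyond the scatter) and a 10-fold higher number from compound 1 to compound 3 (1.00 log units; beyond the scatter) both lie beyond it. Every one of these measured steps changes the ring on the double-bonded chain carbon; none alters the (4-bromophenyl)carbonyl part.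

Compound 4 `O=C(/C(=C\c1ccc(O)cc1)SCc1ccc(F)cc1)c1ccc(Cl)cc1` differs from compound 3 in exactly one place: chloro in place of bromo on an aromatic carbon. Among the measured compounds shown here, no measured step bears on this exchange, since bromo is kept in all three measured compounds. Chloro and bromo are each a single heavy atom with no donors or acceptors, so the change is small in what is counted, and with nothing measured to argue for a shift in either direction the expectation is a step no larger than the scatter. Compound 4 is therefore expected to give about 10000 nM, with a likely range from 4000 nM to 25000 nM. The expected step is no change at the digits printed from compound 3 to compound 4 (within the scatter), a change within the scatter.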

Compound 4, concentration for 50% growth inhibition: 25000 nM
The estimate for compound 4 lay 2.5-fold (0.40 log units) below the measured number, within the range that was stated.
By their numbers in this assay, from the lowest: compound 1; then compounds 2 and 3 (each within the scatter of the next); then compound 4.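

Until now, every measured step changed the ring on the double-bonded chain carbon, so nothing showed whether the other end of the molecule matters. In this assay, the exchange of bromo for chloro gives a 2.5-fold higher number from compound 3 to compound 4 (0.40 log units; beyond the scatter), so this position does affect the read-out, and within this one pair the bromo compound is the stronger inhibitor of growth. The step is modest, yet it arises from replacing one heavy atom with another, with no ring, hydrogen-bond donor, hydrogen-bond acceptor or net charge entering or leaving, and nothing measured here gives a reason for it.

This single pair carries the 4-hydroxyphenyl ring, so the compounds shown leave open whether the same exchange would give a step of similar size and direction alongside the 3-hydroxy-4-methoxyphenyl ring of compound 1, which has the lowest number of the set. They also leave open how other groups at this place on the ring would compare with bromo and chloro, such as a methoxy group, an amine or a carboxylic acid.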